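Swapping the aryl ring of a sulfonate ester

The compounds below may be only part of what the source reports. "The series", "measured", "known", "first", "only" and "open" are said of these compounds alone.

Compound 3 `CCCN1CCN(c2ccc(S(=O)(=O)Oc3ccccc3CC)cc2)C1=O` gives 2300 nM in a functional assay on MCF7 cells (Homo sapiens) for antiproliferative activity, read by sulforhodamine B assay, with a stated time of 48 h (a lower number here means a stronger inhibitor, a higher number a weaker inhibitor), the lowest of the two numbers in hand. Compound 1 `CCc1ccccc1OS(=O)(=O)c1ccc(N2CCN(C)C2=O)cc1` gives 26000 nM, and an 11-fold lower number from compound 1 to compound 3 (1.05 log units; beyond the scatter). Compound 2 `CCN1CCN(c2ccc(S(=O)(=O)Oc3ccc(OC)cc3)cc2)C1=O` reaches only the limit > 100000 nM, a limit and not a number (the limit of > 100000 nM in this assay, at which 1 of the 3 values shown sits). Compound 4 `CCCN1CCN(c2ccc(S(=O)(=O)Oc3ccc(F)cc3)cc2)C1=O` carries the change (4-fluorophenyl in place of 2-ethylphenyl on an oxygen). Going by the values given here, no measured step covers this change alone; compound 2 differs from compound 3 in two places, so its two values show only that a different aryl ring went with a limit. The expected outcome is a weaker compound 4, with a 6.5-fold higher number from compound 3 to compound 4 (0.81 log units; beyond the scatter) estimated. Compound 4 is expected at 15000 nM, within 4000 nM to 90000 nM.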

Compound 4, half-maximal inhibitory concentration: 33000 nM
Compound 4: the middle estimate sits 2.2-fold (0.34 log units) below what was measured; measured number inside the range.
By their numbers in this assay, from the lowest: compound 3; then compounds 1 and 4 (each within the scatter of the next). At a limit, above all of these: compound 2.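

On the oxygen of the sulfonate ester, the aryl group alone can move the number a long way: with the rest of the molecule unchanged, 4-fluorophenyl in place of 2-ethylphenyl gives a 14-fold higher number from compound 3 to compound 4 (1.16 log units; beyond the scatter). This is the only measured step shown that changes this aryl group by itself. Nothing measured here accounts for its size.

As far as these compounds go, since the ethyl group leaves and the fluorine enters in one step, their separate contributions remain open. So does how an amine or a carboxylic acid on this ring would read.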